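Replacing an ethyl group with a chlorophenyl ring on a thiourea

The source may report more compounds than this note shows. Statements on the series, on what has been measured and on what is new or still open speak of the compounds shown alone.

This series shares a thiourea core carrying a trifluoromethylphenyl group on one nitrogen. Compound 1 `FC(F)(F)c1cccc(NC(=S)Nc2cccc(Br)c2)c1` has a 3-bromophenyl on the other nitrogen, compound 2 `Fc1ccccc1NC(=S)Nc1cccc(C(F)(F)F)c1` a 2-fluorophenyl, and compound 3 `CCNC(=S)Nc1cccc(C(F)(F)F)c1` an ethyl. In an ADME assay on Vero 76 cells (Chlorocebus sabaeus) for cytotoxicity, read by crystal violet staining, with a stated time of 96 h (a higher number here means that more compound is tolerated, a lower number that less compound is tolerated), compound 1 gives 14000 nM and compound 2 gives 64000 nM. For compound 3 this assay reports only a limit, > 100000 nM. Compound 3 thus sits at the top of the numbers shown, at the limit of > 100000 nM in this assay, at which 1 of the 3 values shown sits.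

Compound 4 `FC(F)(F)c1cccc(NC(=S)Nc2ccc(Cl)cc2)c1` is the next step: 4-chlorophenyl in place of ethyl on an amide-type nitrogen. The measured steps run the other way, from an aryl group to ethyl: an at least 7.1-fold higher number from compound 1 to compound 3 (0.85 log units; beyond the scatter) and an at least 1.5-fold higher number from compound 2 to compound 3 (0.19 log units; that floor lies within the scatter). Reversing that direction, putting a halogenated phenyl ring back in place of ethyl, should therefore lower the tolerated concentration, most likely by an amount resembling the step from compound 1.

Compound 4 is expected to land at 20000 nM, with a range of 7000 nM to 70000 nM, which means an estimated step of an at least 5.0-fold lower number from compound 3 to compound 4 (0.69 log units; beyond the scatter).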

Compound 4, half-maximal cytotoxic concentration: 11000 nM
Beside the measured number, compound 4's estimate is 1.8-fold (0.26 log units) above it; the measured number falls inside the stated range.
By their numbers in this assay, from the lowest: compounds 4 and 1 (each within the scatter of the next); then compound 2. At a limit, above all of these: compound 3.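

Compound 3 still stands at a limit of the assay, not at a number: the limit of > 100000 nM in this assay, at which 1 of the 4 values shown sits.

Putting 4-chlorophenyl on the amide-type nitrogen in place of ethyl gives an at least 9.0-fold lower number from compound 3 to compound 4 (0.95 log units; beyond the scatter), so the drop already seen with 3-bromophenyl also appears with a different halogen on the ring. Not every halogenated phenyl ring behaves alike in this assay, however: 4-chlorophenyl in place of 2-fluorophenyl gives a 5.8-fold lower number from compound 2 to compound 4 (0.76 log units; beyond the scatter), while 4-chlorophenyl in place of 3-bromophenyl gives a 1.3-fold lower number from compound 1 to compound 4 (0.10 log units; within the scatter).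

With the halogen and its place on the ring changing together across compound 1, compound 2 and compound 4, the compounds shown cannot separate the two. They also leave open how an unsubstituted phenyl ring, a longer chain such as butyl, or a phenyl ring carrying an amine would fare at this nitrogen.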